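Cyclobutyl in Place of Propyl on the Amide Carbonyl

The source may report more compounds than this note shows. Statements on the series, on what has been measured and on what is new or still open speak of the compounds shown alone.

Compound 1 `Cc1cccc(Cn2c(CN3CCN(C(=O)C(C)C)CC3)nc3ccccc32)c1` gives 87.2% in an assay on isolated protein for inhibition of aldehyde dehydrogenase 1A1 (Homo sapiens), read by spectrophotometry, tested at 10 uM; a lower number here means less inhibition, a higher number more inhibition at the concentration tested (going by the name of the read-out). Compound 2 `CCCC(=O)N1CCN(Cc2nc3ccccc3n2Cc2cccc(C)c2)CC1` gives 79.1% in this assay.

Compound 2 holds the lower of the two numbers, yet its value and that of compound 1 lie within the usual scatter of each other. Compound 3 `Cc1cccc(Cn2c(CN3CCN(C(=O)C4CCC4)CC3)nc3ccccc32)c1` differs from compound 2 by cyclobutyl in place of propyl on a carbonyl carbon. Within the data shown here, the only measured step, a number 8.1 percentage points lower from compound 1 to compound 2 (within the scatter), also exchanged one small alkyl group for another on the same carbonyl carbon and stayed within the scatter, so a further alkyl exchange there is expected to move this assay little or not at all. The estimate for compound 3 is 80%, with a range from 65% to 92%. The expected step is a number 0.9 percentage points higher from compound 2 to compound 3 (within the scatter).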

Compound 3, a percentage reported as inhibition, at one concentration (the size of the read-out at that concentration, not a potency): 69.1%
Beside the measured number, compound 3's estimate is 10.9 percentage points above it; the range from low to high includes it.
By their numbers in this assay, from the lowest: compounds 3, 2 and 1 (each within the scatter of the next, the first and the last beyond it).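

Cyclobutyl in place of isopropyl on the carbonyl carbon is the only step shown that passes the usual scatter in this assay, with a number 18.1 percentage points lower from compound 1 to compound 3 (beyond the scatter). Cyclobutyl in place of propyl stays within it, with a number 10 percentage points lower from compound 2 to compound 3 (within the scatter), so this position is not wholly indifferent to the alkyl group, although the evidence is a single step. Nothing available explains why.

As far as these compounds go, whether a cyclopentyl or cyclohexyl group, or a ring containing oxygen such as tetrahydropyranyl, would give a number nearer compound 1 or compound 3 remains open.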